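Series notes: benzyl to propyl on the indazole nitrogen

This account rests on a few compounds, and the source may have more. Where it says the series, first, only, none or still open, it means among the compounds named here.

Compound 1 `CCOC(=O)c1ccc(-c2nn(Cc3ccccc3Cl)c3ccccc23)cc1` is assessed in a functional assay on cells (Platelet, Homo sapiens) for inhibition; a lower number here means a stronger inhibitor, a higher number a weaker inhibitor. In this assay compound 1 reaches only the limit of > 10000 nM, so no number is known for it. Compound 2 `CCOC(=O)c1ccc(-c2nn(Cc3ccccc3OC)c3ccccc23)cc1` carries methoxy in place of chloro on an aromatic carbon. In this assay compound 2 likewise stops at the limit of > 10000 nM. The step that the two limits leave unreadable from compound 1 to compound 2 therefore cannot be sized, because the limit of > 10000 nM in this assay, at which 2 of the 2 values shown sit, is all that the two values give. Compound 3 `CCCn1nc(-c2ccc(C(=O)OCC)cc2)c2ccccc21` differs from compound 1 by ethyl in place of 2-chlorophenyl on a saturated chain carbon bound to an aromatic nitrogen. Among the measured compounds shown here, the only measured step bears on a change at a different position and is itself unreadable, so no measured step sizes the change from compound 1 to compound 3. Both values in hand sit at the limit, which is the sole basis for any expectation here. Compound 3 is therefore expected, most likely, to remain at the limit as well, estimated at 10000 nM within 3000 nM to 30000 nM. The step of a number no higher from compound 1 to compound 3 (the limit leaves the size open) expected on this basis is no more than nominal, with a clear chance that the assay again reports only a limit.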

Compound 3, half-maximal inhibitory concentration: > 10000 nM
Compound 3 gave a limit, no number; the forecaster's own chance of this, stated with the estimate: 80%; the middle value sits exactly at the limit.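

The steps from compound 1 and from compound 2 to compound 3 cannot be read in this assay, since each value is a limit and not a number: the limit of > 10000 nM in this assay, at which 3 of the 3 values shown sit. From the compounds shown here alone, whether compound 1, compound 2 and compound 3 differ at all in inhibition stays open, and with it any effect of the 2-chlorobenzyl to propyl change.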